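A few compounds are considered here, and "the series" means these few. Any claim that something is new, unique, unknown or untested is made for them only; others in the source may bear on it.

Compound 3 `CCCC(O)CC(=O)O[C@H](CC=C(C)C)C1=CC(=O)c2c(O)ccc(O)c2C1=O` is one of three esters built on the shared core that have been tested in a functional assay on DU-145 cells (Homo sapiens) for cytotoxicity, read by MTT assay; a lower number here means a stronger inhibitor, a higher number a weaker inhibitor. For compound 3 this assay gives only a limit, > 100000 nM. Compound 2 `CC(C)=CC[C@@H](OC(=O)c1ccco1)C1=CC(=O)c2c(O)ccc(O)c2C1=O` likewise reaches only a limit, > 100000 nM. Among the compounds with values here, compound 1 `CC(C)=CC[C@@H](OC(=O)CCO)C1=CC(=O)c2c(O)ccc(O)c2C1=O` is the sole member with a number, giving 55300 nM. Both steps away from it, an at least 1.8-fold higher number from compound 1 to compound 3 (0.25 log units; that floor lies within the scatter) and an at least 1.8-fold higher number from compound 1 to compound 2 (0.25 log units; that floor lies within the scatter), rest on (the limit of > 100000 nM in this assay, at which 2 of the 3 values shown sit), and a step that the two limits leave unreadable from compound 2 to compound 3.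

Compound 4 `CC(C)=CC[C@@H](OC[C@@H](C)O)C1=CC(=O)c2c(O)ccc(O)c2C1=O` replaces the ester of compound 3 by an ether: 2-hydroxypropyl in place of (2-hydroxypentyl)carbonyl on an oxygen on a saturated carbon. Within the data shown here, no measured step touches a change of this kind, so the expectation leans on compound 1, whose 55300 nM shows that a short hydroxylated group here yields a number. Compound 4 is therefore expected to land near 60000 nM, within 20000 nM to 200000 nM, a step of an at least 1.6-fold lower number from compound 3 to compound 4 (0.22 log units; that floor lies within the scatter) that is merely estimated.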

Compound 4, half-maximal inhibitory concentration: 14300 nM
Compound 4: the middle estimate sits 4.2-fold (0.62 log units) above what was measured; the measured number lies below the stated range.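

Within the data shown here, exchanging the acyl groups on this oxygen for 2-hydroxypropyl gives the first steps at this position that lie beyond the scatter, and only one of them joins two real numbers (a 3.9-fold lower number from compound 1 to compound 4 (0.59 log units; beyond the scatter)). The other two are floors (an at least 6.9-fold lower number from compound 3 to compound 4 (0.84 log units; beyond the scatter)) and (an at least 6.9-fold lower number from compound 2 to compound 4 (0.84 log units; beyond the scatter)), set by an assay limit: (the limit of > 100000 nM in this assay, at which 2 of the 4 values shown sit). The number at this position can therefore fall with no carbonyl on the oxygen.

The compounds shown do not separate the ether link from the chain it carries. On these data alone, how an amine or a longer ether chain on this oxygen would read stays open.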